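Swapping a Pentyl Chain for Methoxy on a Shared Core

The compounds below may be only part of what the source reports. "The series", "measured", "known", "first", "only" and "open" are said of these compounds alone.

Measured so far:
compound 1, `O=C(NN1CCCCCC1)C1=NN(c2ccc(Cl)cc2Cl)C(c2ccc(Cl)cc2)C1`: 8.4%
compound 2, `O=C(NN1CCOCC1)C1=NN(c2ccc(Cl)cc2)C(c2ccc(Cl)cc2)C1`: 8.1%
compound 3, `CCCCCc1ccc(C2CC(C(=O)NN3CCOCC3)=NN2c2ccc(Cl)cc2Cl)cc1`: 13.1%

All three numbers come from a functional assay on the whole organism (strain Zucker) for inhibition, with Rattus norvegicus as the target, with a stated time of 4 h, at a dose of 10 mg/kg by the oral route (on this read-out higher numbers stand for more inhibition at the one dose given (going by the name of the read-out) and lower numbers for less inhibition), and all three are small. Compound 3 has the highest number of the three, but its gap to compound 1 and its gap to compound 2 both lie within the usual scatter of repeated measurements, so no order among the three can be claimed; they read as one low cluster.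

Compound 4, `COc1ccc(C2CC(C(=O)NN3CCOCC3)=NN2c2ccc(Cl)cc2Cl)cc1`, has not been measured yet. It is compound 3 with one change: methoxy in place of pentyl on an aromatic carbon

Among the compounds with values here, no step between two measured compounds separates the effect of this change from anything else, so there is nothing in the data to suggest a move in either direction. The expectation is therefore that the step of a number 3.1 percentage points lower from compound 3 to compound 4 (within the scatter) stays within the scatter. On that basis compound 4 is estimated to give about 10% in this assay, with a likely range from 0% to 25%.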

Compound 4, a percentage reported as inhibition, in the whole organism at one dose (the size of the read-out at that dose, not a potency): 9.4%
For compound 4 the middle estimate is 0.6 percentage points above the measured one; measured number inside the range.
By their numbers in this assay, from the lowest: compounds 2, 1, 4 and 3 (each within the scatter of the next).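

In this assay, within the data shown here, the 4-pentylphenyl to 4-methoxyphenyl exchange gives a number 3.7 percentage points lower from compound 3 to compound 4 (within the scatter), the first reading in this set of a single change on its own. On this aromatic carbon, para to a large group, pentyl with its 5 heavy atoms and methoxy with its 2 heavy atoms and 1 hydrogen-bond acceptor cannot be told apart in this whole-animal test at this one dose, and both compounds stay in the same low cluster. No supporting measurement is available to explain this result.

Still open, on these data alone, is whether a carboxylic acid or an amine on this carbon would lift the number clear of that cluster. Among these compounds, with only two groups compared here, a reading this flat does not show whether this position matters in general.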